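Cyclopentyl gives way to 4-methoxyphenyl at an unreadable limit

This account rests on a few compounds, and the source may have more. Where it says the series, first, only, none or still open, it means among the compounds named here.

Compound 1 `COc1ccc(C(=O)n2c(C(C)C)nc3ccccc32)cc1`: > 10000 nM
Compound 2 `COc1ccc(C(=O)n2c(C3CCCC3)nc3ccccc32)cc1`: > 10000 nM

Both entries come from a functional assay on HeLa cells (Homo sapiens) for cytotoxicity, read by MTT assay, with a stated time of 72 h (a lower number here means a stronger inhibitor, a higher number a weaker inhibitor), and each is a limit of the assay, not a number. Compound 2 therefore has no exact value of its own: it sits at the limit of > 10000 nM in this assay, at which 2 of the 2 values shown sit. Placing cyclopentyl where isopropyl stood on an aromatic carbon gave a step that the two limits leave unreadable from compound 1 to compound 2. Going by the values given here, this is the only measured step that bears on the next change, and it offers no size to carry forward.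

Compound 3 `COc1ccc(C(=O)n2c(-c3ccc(OC)cc3)nc3ccccc32)cc1` has not yet been measured. It changes the same carbon again: 4-methoxyphenyl in place of cyclopentyl on an aromatic carbon. An aromatic ring now replaces a non-aromatic one, a kind of change that neither measured compound tests.

The expectation rests on compound 2 at > 10000 nM, a limit, so no clear step in either direction is expected in this assay, though a real gain in strength cannot be ruled out. The expected step is a step that the limit leaves unreadable from compound 2 to compound 3, a rough estimate. For compound 3 the estimated value is 12000 nM, with an expected range of 3000 nM to 40000 nM.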

Compound 3, half-maximal inhibitory concentration: > 10000 nM
Compound 3: no number, only a limit (the forecaster's own chance of this, stated with the estimate: 70%); the middle value is on the limit's open side.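

Compound 3, like compound 1 and compound 2, gives only a limit and not a number in this assay, so no step among the three can be read: the limit of > 10000 nM in this assay, at which 3 of the 3 values shown sit.

The compounds shown leave open whether isopropyl, cyclopentyl and 4-methoxyphenyl differ at all in this assay, and whether any group on this carbon would give a readable number.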